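The compounds below may be only part of what the source reports. "The series", "measured", "known", "first", "only" and "open" are said of these compounds alone.

Values in a functional assay on CCRF-CEM cells (Homo sapiens) for inhibition; a lower number here means a stronger inhibitor, a higher number a weaker inhibitor:
compound 1 `CC(O)n1cnc2c(N)nc(I)nc21` gives 465000 nM
compound 2 `Nc1nc(I)nc2c1ncn2OCCO` gives > 500000 nM, which is a limit of the assay
compound 3 `CC(O)n1cnc2c(S)nc(F)nc21` gives > 500000 nM, which is a limit of the assay

Compound 1 and compound 2 differ by 2-hydroxyethoxy in place of 1-hydroxyethyl on an aromatic nitrogen. The step of an at least 1.0-fold higher number from compound 1 to compound 2 (0.03 log units; that floor lies within the scatter) lies within the usual scatter, so the two values show no ordering between them. The core of compound 3 differs from the core of compound 1, and the difference between the two cores is not broken down here.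

Compound 4 `OCCOn1cnc2c(S)nc(F)nc21` is not yet measured in this assay. It differs from compound 3 by 2-hydroxyethoxy in place of 1-hydroxyethyl on an aromatic nitrogen, the same change as that made from compound 1 to compound 2, at the same place. For compound 4 in this assay a step that the limit leaves unreadable from compound 3 to compound 4 is expected, resting on the earlier step of an at least 1.0-fold higher number from compound 1 to compound 2 (0.03 log units; that floor lies within the scatter) from the same change, which stayed within the scatter. Because compound 3 already sits at the limit of > 500000 nM in this assay, at which 2 of the 3 values shown sit, compound 4 is expected most likely to return only a limit as well. The estimate for compound 4 is 600000 nM, with a range from 300000 nM to 1500000 nM.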

Compound 4, half-maximal inhibitory concentration: 117000 nM
The estimate for compound 4 lay 5.1-fold (0.71 log units) above the measured number; the measured number lies below the stated range.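

In this assay, 2-hydroxyethoxy in place of 1-hydroxyethyl on an aromatic nitrogen gives an at least 4.2-fold lower number from compound 3 to compound 4 (0.63 log units; beyond the scatter). The change therefore does not carry the same outcome from one core to the other: the same change on two cores in this assay, an at least 1.0-fold higher number (0.03 log units; that floor lies within the scatter) from compound 1 to compound 2 and an at least 4.2-fold lower number (0.63 log units; beyond the scatter) from compound 3 to compound 4, at least 4.5-fold (0.66 log units) apart, beyond the scatter of two such steps Compound 3 gives > 500000 nM, which is a limit, so the step has only a floor, and the comparison shows neither its true size nor which feature of the core goes with the different outcome.

Open, on these data alone, is whether the lower number of compound 4 belongs to the 2-hydroxyethoxy group alone or needs the whole core of compound 3, which would take cores differing from it in one place to settle. Also open, as far as these compounds go, is how this assay responds on that core when the same aromatic nitrogen carries a longer chain such as 3-hydroxypropoxy, or an amine-bearing chain such as 2-aminoethoxy.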